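Moving the Sulfonyl Halogen: Compound 2 to Compound 4

The source may report more compounds than this note shows. Statements on the series, on what has been measured and on what is new or still open speak of the compounds shown alone.

Compound 1, `Cc1ccc(S(=O)(=O)n2cc(C3CNC(C4CCCCC4)=N3)c3ccccc32)cc1`: in an assay on isolated protein for inhibition of kallikrein-7 (Homo sapiens), read by fluorescence, with stated times of 10 min and 30 min (on this read-out lower numbers stand for stronger inhibition and higher numbers for weaker inhibition), compound 1 gives > 100000 nM, which is a limit of the assay rather than a number.
Compound 2, `CC1=NC(c2cn(S(=O)(=O)c3ccc(Cl)cc3)c3ccc(C)cc23)CN1`: in this assay compound 2 gives 1900 nM.
Compound 3, `CC1=NC(c2cn(S(=O)(=O)c3ccc(Cl)cc3)c3ccc(Br)cc23)CN1`: in this assay compound 3 gives 4700 nM.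

Among the two numbers given, compound 2 has the lowest; the nearest is compound 3, reached by a 2.5-fold higher number from compound 2 to compound 3 (0.39 log units; beyond the scatter), with bromo in place of methyl on an aromatic carbon. Compound 1 sits at the limit of > 100000 nM in this assay, at which 1 of the 3 values shown sits.

Compound 4, `CC1=NC(c2cn(S(=O)(=O)c3ccccc3Br)c3ccc(C)cc23)CN1`, differs from compound 2 in one place: 2-bromophenyl in place of 4-chlorophenyl on a sulfonyl sulfur. Among the measured compounds shown here, no measured step touches this part of the molecule; the only measured step changes a group on the shared core, and compound 1 differs from compound 2 in several places at once. The direction of the step therefore cannot be read from the measured compounds, and a modest weakening is expected, a 1.8-fold higher number from compound 2 to compound 4 (0.27 log units; within the scatter). Compound 4 is estimated at 3500 nM, with a range from 900 nM to 15000 nM.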

Compound 4, half-maximal inhibitory concentration: 390 nM
Estimate against measurement, compound 4: 9.0-fold (0.95 log units) above, outside the stated range (below it).
By their numbers in this assay, from the lowest: compound 4; then compound 2; then compound 3. At a limit, above all of these: compound 1.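

The group on the sulfonyl sulfur turns out to matter in this assay: 2-bromophenyl in place of 4-chlorophenyl gives a 4.9-fold lower number from compound 2 to compound 4 (0.69 log units; beyond the scatter). Among the compounds shown here, this is the first measured change at this part of the molecule, and it runs in the opposite direction to the change on the shared core, where bromo in place of methyl gives a 2.5-fold higher number from compound 2 to compound 3 (0.39 log units; beyond the scatter). Nothing measured in these compounds explains why the number falls with this change.

The step swaps the halogen and its place on the phenyl ring together, so the compounds shown cannot say which of the two matters, and only 2-chlorophenyl or 4-bromophenyl on the same sulfur could separate them. Also open, going by these compounds, is whether this part of the molecule accepts a quite different group, such as an amine or a carboxylic acid on that phenyl ring.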